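This account rests on a few compounds, and the source may have more. Where it says the series, first, only, none or still open, it means among the compounds named here.

Measured compounds:
- Compound 1, `O=C(Nc1ccc(F)cc1)N[C@H]1CC[C@H](Oc2ccc(F)cc2)CC1`: 20000 nM
- Compound 2, `O=C(Nc1ccc([N+](=O)[O-])cc1)N[C@H]1CC[C@H](Oc2ccc(F)cc2)CC1`: 2300 nM

In a functional assay on CRL2813 cells (Homo sapiens) for cytotoxicity, read by sulforhodamine B assay, with a stated time of 5 days (a lower number here means a stronger inhibitor, a higher number a weaker inhibitor), compound 1 gives 20000 nM and stands highest of the two numbers; its nearest neighbour is compound 2, which in this assay gives 2300 nM. Among the compounds with values here, the single step between them, an 8.7-fold lower number from compound 1 to compound 2 (0.94 log units; beyond the scatter), is beyond the scatter and is the only step in the set.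

Compound 3, `O=C(Nc1ccccc1Cl)N[C@H]1CC[C@H](Oc2ccc(F)cc2)CC1`, is not yet measured in this assay. It differs from compound 1 by 2-chlorophenyl in place of 4-fluorophenyl on an amide-type nitrogen. The change sits on the same amide-type nitrogen as the step from compound 1 to compound 2, but the group that enters is different, so that step bears only loosely on it: it shows that a change at this place can move the number by roughly that much, not in which direction a 2-chlorophenyl would move it. A step of modest size, or none beyond the scatter, is therefore expected, with no strong lean to either side; the estimate is set somewhat lower, a 2.0-fold lower number from compound 1 to compound 3 (0.30 log units; within the scatter), with a wide range.

Compound 3 is expected to give 10000 nM in this assay, between 3000 nM and 35000 nM.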

Compound 3, half-maximal inhibitory concentration: 9100 nM
Estimate against measurement, compound 3: 1.1-fold (0.04 log units) above, and the stated range covers the measured number.
By their numbers in this assay, from the lowest: compound 2; then compound 3; then compound 1.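

In this assay, the change at the amide-type nitrogen need not involve a nitro group to move the number beyond the scatter: replacing one halogen-bearing phenyl group with another gives a 2.2-fold lower number from compound 1 to compound 3 (0.34 log units; beyond the scatter). The other new step, a 4.0-fold higher number from compound 2 to compound 3 (0.60 log units; beyond the scatter), shows that 2-chlorophenyl does not match 4-nitrophenyl here, so the three aryl groups at this place now give three separable numbers, with 2-chlorophenyl in the middle. Nothing available explains this order at the amide-type nitrogen.

The change from 4-fluorophenyl to 2-chlorophenyl alters the halogen and its numbered ring place together, so the compounds shown cannot divide the step between these two changes; 4-chlorophenyl and 2-fluorophenyl would separate them. Going by these compounds, it also remains open whether the order holds for an unsubstituted phenyl, or for a phenyl ring bearing an amine or a carboxylic acid, and whether any of these steps would be the same with a group other than the 4-fluorophenyl on the oxygen of the shared core.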